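Next step from compound 2: new group on the ring amine

The compounds below may be only part of what the source reports. "The series", "measured", "known", "first", "only" and "open" are said of these compounds alone.

Compound 1 `CC(C)(C)OC(=O)N1CCC(O[C@H]2CC[C@H](Oc3cnc(C#N)cn3)CC2)CC1` gives 28.4 nM in a functional assay on isolated protein for agonist activity at Glucose-dependent insulinotropic receptor (Rattus norvegicus), read by HTRF and cAMP accumulation; a lower number here means that less compound is needed, a higher number that more compound is needed for the effect. Compound 2 `C[C@H](CF)OC(=O)N1CCC(O[C@H]2CC[C@H](Oc3cnc(S(C)(=O)=O)cn3)CC2)CC1` stands highest of the two numbers shown, giving 317 nM in this assay; compound 1 sits lower by a margin beyond the scatter. Compound 3 `CC(C)c1noc(CN2CCC(O[C@H]3CC[C@H](Oc4cnc(S(C)(=O)=O)cn4)CC3)CC2)n1` differs from compound 2 in one place: a group of 9 heavy atoms (6 carbon, 2 nitrogen, 1 oxygen; one five-membered aromatic ring with 3 hetero atoms) in place of a group of 7 heavy atoms (4 carbon, 2 oxygen, 1 fluorine; no ring), on an amine nitrogen in a ring. For the measured compounds named here, no measured pair covers this change, so the expected step of a 1.3-fold lower number from compound 2 to compound 3 (0.10 log units; within the scatter) in this assay is taken as small, of uncertain direction, and probably not beyond the scatter. Compound 3 is therefore estimated at 250 nM in this assay, within 60 nM to 1000 nM.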

Compound 3, half-maximal effective concentration: 97.9 nM
Estimate against measurement, compound 3: 2.6-fold (0.41 log units) above; measured number inside the range.
By their numbers in this assay, from the lowest: compound 1; then compound 3; then compound 2.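

In this assay, (3-isopropyl-1,2,4-oxadiazol-5-yl)methyl on the ring amine nitrogen in place of the ring-free group gives a 3.2-fold lower number from compound 2 to compound 3 (0.51 log units; beyond the scatter). This position therefore tolerates a five-membered aromatic ring with the rest of the shared core unchanged, and the change improves the number. Nothing available explains this step.

Still open, as far as these compounds go, is how much of the step belongs to the isopropyl group, the aromatic ring or the methylene link; a cyclopropyl in place of isopropyl would test the first. From the compounds shown here alone, whether the gain carries over to a core bearing the nitrile also remains unknown.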